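The source may hold more compounds than are shown below. What is called first, only, known or untested is meant among the compounds shown, and "the series" means these compounds.

The measured compounds, each with its result in an assay on microsomes from liver for inhibition of 3-hydroxy-3-methylglutaryl-coenzyme A reductase (Rattus norvegicus); a lower number here means a stronger inhibitor, a higher number a weaker inhibitor:

Compound 1 `O=C(O)C[C@H](O)C[C@H](O)CCn1c(C(F)(F)F)nc(-c2ccccc2)c1-c1ccc(F)cc1`: 31 nM
Compound 2 `Cc1cccc(-c2nc(C(F)(F)F)n(CC[C@@H](O)C[C@@H](O)CC(=O)O)c2-c2ccc(F)cc2)c1`: 29 nM
Compound 3 `O=C(O)C[C@H](O)C[C@H](O)CCn1c(C(F)(F)F)nc(-c2cccs2)c1-c1ccc(F)cc1`: 64 nM

Compound 3 has the highest number of the three in this assay. The step from compound 1 to compound 3 is a 2.1-fold higher number from compound 1 to compound 3 (0.31 log units; beyond the scatter), and the step from compound 2 to compound 3 is a 2.2-fold higher number from compound 2 to compound 3 (0.34 log units; beyond the scatter); both put the five-membered thiophen-2-yl ring behind the six-membered rings at the same place.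

Compound 4 `O=C(O)C[C@H](O)C[C@H](O)CCn1c(C(F)(F)F)nc(-c2cccnc2)c1-c1ccc(F)cc1` is the next compound. The change from compound 3 is pyridin-3-yl in place of thiophen-2-yl on an aromatic carbon. The two steps above bear on it: each swaps the group at this one place between a five-membered ring and a six-membered ring, and each was modest in size. Since the group that enters is again one six-membered aromatic ring with 1 hetero atom, a modest move toward a lower number is expected, though the single hetero atom in that ring makes the size uncertain. The estimated step from compound 3 to compound 4 in this assay is a 1.4-fold lower number from compound 3 to compound 4 (0.15 log units; within the scatter). Compound 4 is therefore expected to give about 45 nM in this assay, most likely between 20 nM and 110 nM.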

Compound 4, half-maximal inhibitory concentration: 66 nM
Estimate against measurement, compound 4: 1.5-fold (0.17 log units) below; low and high end bracket the measured number.
By their numbers in this assay, from the lowest: compounds 2 and 1 (each within the scatter of the next); then compounds 3 and 4 (each within the scatter of the next).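

In this assay, among the compounds shown here, a six-membered ring at this position, next to the ring nitrogen, does not by itself keep the number low, which the earlier compounds could not show. Going from thiophen-2-yl to pyridin-3-yl gives a 1.0-fold higher number from compound 3 to compound 4 (0.01 log units; within the scatter) while going from the other six-membered rings gives a 2.1-fold higher number from compound 1 to compound 4 (0.33 log units; beyond the scatter) and a 2.3-fold higher number from compound 2 to compound 4 (0.36 log units; beyond the scatter) so compound 4 goes against the reading that six-membered rings do better here than five-membered ones. No evidence at hand explains this result.

The compounds shown leave open whether the place of the ring nitrogen matters, which pyridin-2-yl or pyridin-4-yl would test. They also leave open how an amine or a carboxylic acid on the phenyl ring would compare with the methyl of compound 2.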